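This account rests on a few compounds, and the source may have more. Where it says the series, first, only, none or still open, it means among the compounds named here.

Compounds measured so far:

Compound 1, `CCCSc1nc(N/N=C(\C)c2ccccc2O)c2nnn(Cc3ccccc3Cl)c2n1`, in a functional assay on MCF7 cells (Homo sapiens) for antiproliferative activity, read by MTT assay, with a stated time of 72 h (a lower number here means a stronger inhibitor, a higher number a weaker inhibitor), compound 1 gives > 64000 nM, a limit of the assay rather than a number.
Compound 2, `C#CCSc1nc(N/N=C/c2cc(OC)c(OC)c(OC)c2)c2nnn(Cc3ccccc3)c2n1`, in this assay compound 2 gives 17000 nM.
Compound 3, `CCCSc1nc(N/N=C/c2cccs2)c2nnn(Cc3ccccc3)c2n1`, in this assay compound 3 gives > 64000 nM, again a limit of the assay and not a number.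

Compound 1 thus stands at the limit of this assay; of the three values shown, two sit there, as the limit of > 64000 nM in this assay, at which 2 of the 3 values shown sit, records, and only compound 2 returns a number at all. For the measured compounds named here, nothing measured here differs from compound 1 in a single place, so no step between measured compounds can be read off.

Compound 4, `CCCSc1nc(N/N=C(\C)c2ccccc2O)c2nnn(Cc3ccc(F)cc3)c2n1`, differs from compound 1 by 4-fluorophenyl in place of 2-chlorophenyl on a saturated chain carbon bound to an aromatic nitrogen. The hydrazone part and the propylthio group of the shared core are kept. Going by the values given here, with no measured step of this kind on hand, the expectation for compound 4 rests on compound 1 alone, whose value > 64000 nM is a limit. The step from compound 1 to compound 4 is expected to be a number no higher from compound 1 to compound 4 (the limit leaves the size open), that is, none beyond the scatter. Compound 4 is therefore estimated at 64000 nM, with a range from 20000 nM to 200000 nM, and most likely the assay will again report only a limit.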

Compound 4, half-maximal inhibitory concentration: > 64000 nM
Compound 4 gave a limit, no number; the forecaster's own chance of this, stated with the estimate: 70%; the middle value lies on the limit itself.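

In this assay compound 4 gives > 64000 nM, a limit of the assay and not a number. Compound 1 stands at a limit as well, so the step between compound 1 and compound 4 cannot be read. The compounds shown leave open whether 2-chlorobenzyl or 4-fluorobenzyl at this place makes any difference to the value: the limit of > 64000 nM in this assay, at which 3 of the 4 values shown sit.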